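The compounds below may be only part of what the source reports. "The series", "measured", "known", "first", "only" and "open" are said of these compounds alone.

Three measured compounds share one core. Compound 1 `Cn1c(-c2ccccc2)cnc1NC(=O)c1ccc(F)cc1` is the parent. In a toxicity assay on THP-1 cells (Homo sapiens) for inhibition (on this read-out higher numbers stand for lower toxicity in this test and lower numbers for higher toxicity in this test), compound 1 gives > 100000 nM, which is a limit of the assay and not a number. Compound 2 `Cc1ccccc1-c1cnc(NC(=O)c2ccc(F)cc2)n1C` carries a methyl group where compound 1 carries hydrogen. In this assay compound 2 gives > 50000 nM, again a limit rather than a number. The change from compound 2 to compound 1 is hydrogen in place of methyl on an aromatic carbon. The step that the two limits leave unreadable from compound 2 to compound 1 cannot be read because the limit of > 50000 nM in this assay, at which 1 of the 3 values shown sits, and the limit of > 100000 nM in this assay, at which 2 of the 3 values shown sit, are its two ends.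

Compound 3 `COc1ccc(-c2cnc(NC(=O)c3ccc(C)cc3)n2C)cc1` differs from compound 2 in more than one place; the difference between the two cores is not broken down here. In this assay compound 3 gives > 100000 nM, a limit of the assay and not a number.

Compound 4 `COc1ccc(-c2cnc(NC(=O)c3ccccc3)n2C)cc1` has not yet been measured. It differs from compound 3 by hydrogen in place of methyl on an aromatic carbon. That is the same kind of change as from compound 2 to compound 1, though not the same: in the measured pair the methyl sits ortho to a large group, in the new pair para to a large group.

Within the data shown here, for compound 4 the step that the limit leaves unreadable from compound 3 to compound 4 is expected to be small, since the one measured example of this change, a step that the two limits leave unreadable from compound 2 to compound 1, shows no readable movement and compound 3 already sits at a limit with > 100000 nM. Compound 4 is therefore estimated at 150000 nM, with a likely range from 60000 nM to 400000 nM, and most probably only a limit will be reported.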

Compound 4, half-maximal cytotoxic concentration: > 100000 nM
Compound 4 was reported as a limit; the forecaster's own chance of this, stated with the estimate: 85%; the middle value is on the limit's open side.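

In this assay compound 4 gives > 100000 nM, a limit of the assay and not a number. No new step can be read, since compound 3 and compound 4 both stand at the same limit: the limit of > 100000 nM in this assay, at which 3 of the 4 values shown sit.

The compounds shown leave open how far any of them lies from its limit, and whether hydrogen in place of methyl on an aromatic carbon changes the result in this assay at all.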